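Swapping bromo for fluoro in a weak inhibitor of a human mammary epithelial cell line

The source may hold more compounds than are shown below. What is called first, only, known or untested is meant among the compounds shown, and "the series" means these compounds.

Compound 1 `O=C(/C=C/c1ccc(F)c(Br)c1)c1ccc(B(O)O)cc1` was tested in a functional assay on MCF-12A cells (Homo sapiens) for inhibition (on this read-out higher numbers stand for weaker inhibition and lower numbers for stronger inhibition), where compound 1 gives 38000 nM. Compound 2 `O=C(/C=C/c1ccccc1)c1ccc[nH]1` gives 38000 nM, the same number at the digits shown, so the two cannot be told apart within the scatter, and together they carry the highest numbers of the three. Compound 3 `O=C(O)COc1ccc(C(=O)/C=C/c2ccc(Cl)c(Cl)c2)cc1` gives 15000 nM, a clearly lower number, beyond the scatter. Compound 4 `O=C(/C=C/c1ccc(F)c(F)c1)c1ccc(B(O)O)cc1` has not yet been measured. It differs from compound 1 in one place: fluoro in place of bromo on an aromatic carbon. Going by the values given here, no measured pair shows this change, so the size of the step is open. The expectation is that the step of a 1.2-fold higher number from compound 1 to compound 4 (0.07 log units; within the scatter) stays small and within the scatter, with no clear direction. Compound 4 is therefore estimated at 45000 nM, between 15000 nM and 130000 nM.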

Compound 4, half-maximal inhibitory concentration: 39000 nM
Compound 4: middle estimate off by 1.2-fold (0.06 log units), on the high side; the range from low to high includes it.
By their numbers in this assay, from the lowest: compound 3; then compounds 1, 2 and 4 (each within the scatter of the next).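

In this assay, fluoro in place of bromo on this aromatic carbon, ortho to a fluoro group, gives a 1.0-fold higher number from compound 1 to compound 4 (0.01 log units; within the scatter), a step within the scatter. Going by these compounds alone, this is the first pair here that differs in one place, and it shows that this exchange of one halogen for another makes no clear difference at this position. No measurement at hand accounts for the two halogens reading alike. Going by these compounds, whether an amine, a methoxy group or a nitrile at this position would shift the number stays open. So does whether the same exchange would also make no clear difference on another core.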